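Lengthening the Chain from Compound 3 to Compound 4

The source may hold more compounds than are shown below. What is called first, only, known or untested is meant among the compounds shown, and "the series" means these compounds.

Compound 1, `CCCCCCCCCCCCC(C)OC(=O)NC(=O)Nc1c(C(C)C)cccc1C(C)C`, gives 46 nM in an assay on microsomes from intestine for inhibition of acyl-CoA:cholesterol acyltransferase (Oryctolagus cuniculus); a higher number here means a weaker inhibitor, a lower number a stronger inhibitor.
Compound 2, `CC(C)c1cccc(C(C)C)c1OC(=O)NC(=O)Oc1c(C(C)C)cccc1C(C)C`, gives 110 nM in this assay.
Compound 3, `CCCCCCCCC(C)OC(=O)NC(=O)Oc1c(C(C)C)cccc1C(C)C`, gives 270 nM in this assay.

Compound 3 stands highest of the three numbers in this assay, which makes it the weakest inhibitor of the set. Compound 2 is its nearest neighbour, and compound 1 lies furthest from it; both gaps are beyond the scatter of repeated measurements.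

Compound 4, `CCCCCCCCCCCCCCC(C)OC(=O)NC(=O)Oc1c(C(C)C)cccc1C(C)C`, differs from compound 3 in one place: hexyl in place of hydrogen on a saturated chain carbon, nine bonds along the chain from an oxygen next to a carbonyl group. No measured pair carries this same change, so the expectation can only be read off the numbers shown. Compound 1 carries a longer chain than compound 3, though its linkage to the carbonyl differs, and in this assay compound 1 gives 46 nM, which is the lowest number of the set. Compound 4 is therefore expected to move downward from compound 3 by a step beyond the scatter, a 3.0-fold lower number from compound 3 to compound 4 (0.48 log units; beyond the scatter). Compound 4 is estimated at 90 nM, within a range from 30 nM to 270 nM.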

Compound 4, half-maximal inhibitory concentration: 58 nM
Estimate against measurement, compound 4: 1.6-fold (0.19 log units) above; low and high end bracket the measured number.
By their numbers in this assay, from the lowest: compounds 1, 4 and 2 (each within the scatter of the next, the first and the last beyond it); then compound 3.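

Hexyl in place of hydrogen on this saturated chain carbon, nine bonds along the chain from an oxygen next to a carbonyl group, gives in this assay a step beyond the scatter: a 4.7-fold lower number from compound 3 to compound 4 (0.67 log units; beyond the scatter). For the compounds shown here, this is the first pair in the set that differs in one place, so it shows directly that this position responds to the change, and that the added hexyl goes with a stronger inhibitor. No measured evidence shown here accounts for this step.

Going by these compounds, whether the number keeps falling with a still longer chain, or whether a shorter group such as butyl on the same carbon already gives part of the step, stays open. The compounds shown also do not tell how an amine or a carboxylic acid at this position would read in this assay.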